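The source may hold more compounds than are shown below. What is called first, only, known or untested is meant among the compounds shown, and "the series" means these compounds.

Measured compounds:
- compound 1 `COc1cc2c(Oc3ccc(NC(=O)c4cn(-c5ccccc5F)nn4)cc3F)ccnc2cc1OCCCN1CCC(C)CC1`: 130 nM
- compound 2 `COc1cc2c(Oc3ccc(NC(=O)c4cn(-c5c(C)cccc5C)nn4)cc3F)ccnc2cc1OCCCN1CCC(C)CC1`: 4310 nM

In a functional assay on MKN-45 cells (Homo sapiens) for cytotoxicity, read by MTT assay, with a stated time of 72 h (a higher number here means a weaker inhibitor, a lower number a stronger inhibitor), compound 1 gives the lower of the two numbers. Going by the values given here, its only neighbour is compound 2, and the step of a 33-fold higher number from compound 1 to compound 2 (1.52 log units; beyond the scatter) comes from a change on the triazole-bound aryl ring, not on the basic side chain. Compound 3 `COc1cc2c(Oc3ccc(NC(=O)c4cn(-c5ccccc5F)nn4)cc3F)ccnc2cc1OCCCN1CCN(C)CC1` differs from compound 1 in that side chain: 4-methylpiperazin-1-yl in place of 4-methylpiperidin-1-yl on a saturated chain carbon, three bonds along the chain from an oxygen on an aromatic ring. Among the compounds with values here, no measured step touches this part of the molecule, so nothing in the numbers at hand bears directly on the change; the one step that was measured sits elsewhere and gives no guide to its size or direction. Within the data shown here, the change is therefore expected to produce no step in this assay beyond the scatter, with the estimated step of no change at the digits printed from compound 1 to compound 3 (within the scatter). Compound 3 is estimated at 130 nM, within a range from 40 nM to 450 nM.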

Compound 3, half-maximal inhibitory concentration: 140 nM
Compound 3: middle estimate off by 1.1-fold (0.03 log units), on the low side; the range from low to high includes it.
By their numbers in this assay, from the lowest: compounds 1 and 3 (each within the scatter of the next); then compound 2.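

In this assay, placing 4-methylpiperazin-1-yl in place of 4-methylpiperidin-1-yl on a saturated chain carbon, three bonds along the chain from an oxygen on an aromatic ring, gives a 1.1-fold higher number from compound 1 to compound 3 (0.03 log units; within the scatter). Going by these compounds alone, this is the first reading on the side chain: a ring with 2 hetero atoms serves here as well as one with 1 hetero atom, whereas the change on the triazole-bound aryl ring gave a 33-fold higher number from compound 1 to compound 2 (1.52 log units; beyond the scatter). Nothing available explains why the two side chains read alike.

The compounds shown leave open whether the same holds for other amines at this place, such as morpholin-4-yl or dimethylamino, or for a shorter ethyl chain. They also leave open whether the exchange reads the same on the 2,6-dimethylphenyl series.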